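The source may report more compounds than this note shows. Statements on the series, on what has been measured and on what is new or still open speak of the compounds shown alone.

Two compounds of the series have been run in a functional assay on the whole organism with Rattus norvegicus as the target, in the glucose tolerance test; on this read-out lower numbers stand for an effect already at smaller amounts and higher numbers for an effect only at larger amounts of compound. For the measured compounds named here, compound 1, `CCCCCCCCCCCCCCC1(C(=O)OCCCC)CO1`, gives 1.5 mg/kg in this assay, the lowest of the two numbers so far. Compound 2, `COC(=O)C1(CCCCCCCCCCc2ccccc2)CO1`, gives 10 mg/kg in this assay, a higher number than compound 1 by a margin beyond the scatter of repeated runs. No one-point comparison between the measured compounds exists, so the gap between compound 1 and compound 2 shows only what the two values show and supports no pattern.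

Compound 3, `CCCCCCCCCCCCCCC1(C(=O)N(C)C)CO1`, has not been measured. It differs from compound 1 on a carbonyl carbon: dimethylamino in place of butoxy on a carbonyl carbon. Cut one bond further out, the change reads butoxycarbonyl to dimethylcarbamoyl on the shared core; the measured pair says nothing directly about such an exchange. The expected step is a 1.7-fold higher number from compound 1 to compound 3 (0.22 log units; within the scatter), a move toward a somewhat larger dose that may well stay within the scatter. Compound 3 is estimated at 2.5 mg/kg in this assay, with a range from 0.8 mg/kg to 8 mg/kg.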

Compound 3, minimum effective dose: 25 mg/kg
Estimate against measurement, compound 3: 10-fold (1.00 log units) below, outside the stated range (above it).
By their numbers in this assay, from the lowest: compound 1; then compound 2; then compound 3.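

In this assay, for the compounds shown here, dimethylamino in place of butoxy on a carbonyl carbon gives a 17-fold higher number from compound 1 to compound 3 (1.22 log units; beyond the scatter), a large step beyond the scatter and the first comparison in which only one place differs. The group on this carbonyl carbon therefore matters to the dose at which an effect appears: with the rest of the structure held constant, butoxycarbonyl and dimethylcarbamoyl are not interchangeable here. Nothing at hand accounts for the size of this step.

This single exchange changes the linking atom from oxygen to nitrogen and also replaces a group of 5 heavy atoms with one of 3, so the compounds shown cannot tell which of these differences goes with the step, or whether both do. Still open, from the compounds shown here alone, is how the read-out responds on the same core to a dibutylamino group, which keeps the nitrogen with longer chains, to a primary amide, or to a carboxylic acid at this carbonyl carbon.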